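The source may hold more compounds than are shown below. What is called first, only, known or untested is meant among the compounds shown, and "the series" means these compounds.

Measured so far:
Compound 1, `CCOC(=O)c1cc(-c2cccc(OCc3ccccc3)c2)on1`: in an ADME assay on Vero cells (Chlorocebus sabaeus) for cytotoxicity, with a stated time of 72 h (on this read-out higher numbers stand for weaker inhibition and lower numbers for stronger inhibition), compound 1 gives > 128000 nM, which is a limit of the assay and not a number.
Compound 2, `CCOC(=O)c1cc(-c2cccc(OCc3ccc(Cl)c(Cl)c3)c2)on1`: compound 2 has "not determined" (no result reported) in this assay.
Compound 3, `CCOC(=O)c1cc(-c2cccc(OCc3cc(F)ccc3F)c2)on1`: compound 3 gives > 128000 nM in this assay, again a limit and not a number.

Compound 1 therefore stands only at a limit, and of its two companions one stands at the same limit while the other has no result at all. Among the compounds with values here, the one step between measured compounds, a step that the two limits leave unreadable from compound 1 to compound 3, cannot be read in size or direction because both ends rest on (the limit of > 128000 nM in this assay, at which 2 of the 3 values shown sit).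

The untested compound 4 is `CCOC(=O)c1cc(-c2cccc(OCc3ccc(F)c(F)c3F)c2)on1`. It differs from compound 1 as follows: 2,3,4-trifluorophenyl in place of phenyl on a saturated chain carbon bound to an oxygen on an aromatic ring.

Within the data shown here, the only related step, from compound 1 to compound 3, gives no readable size, so no direction beyond the scatter can be claimed for compound 4. The expectation is that compound 4, like compound 1, will be reported at the limit rather than as a number. The estimate for compound 4 in this assay is 150000 nM, with a range from 60000 nM to 400000 nM, meaning an expected step that the limit leaves unreadable from compound 1 to compound 4.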

Compound 4, half-maximal inhibitory concentration: > 128000 nM
Compound 4: a limit, no number; the forecaster's own chance of this, stated with the estimate: 80%; the middle value does not contradict the limit.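

No new step can be read among compound 1, compound 3 and compound 4 in this assay, since each result is a limit and not a number: the limit of > 128000 nM in this assay, at which 3 of the 4 values shown sit.

The compounds shown leave open whether phenyl, 2,5-difluorophenyl and 2,3,4-trifluorophenyl differ at all in this assay.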